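Fluorophenyl triazole sulfonamides: three limits, one isomer pending

The source may hold more compounds than are shown below. What is called first, only, known or untested is meant among the compounds shown, and "the series" means these compounds.

In a functional assay on SGC-7901 cells (Homo sapiens) for antiproliferative activity, read by MTT assay, with a stated time of 24 h (on this read-out lower numbers stand for stronger inhibition and higher numbers for weaker inhibition), compound 1 `O=c1[nH]cc(S(=O)(=O)Nc2cccc(-c3cn(-c4cccc(F)c4)nn3)c2)c(=O)[nH]1` gives only a limit, > 20000 nM. Compound 2 `O=c1[nH]cc(S(=O)(=O)Nc2cccc(-c3cn(-c4ccc(F)cc4)nn3)c2)c(=O)[nH]1` likewise gives only a limit in this assay, > 20000 nM. The change between them is 4-fluorophenyl in place of 3-fluorophenyl on an aromatic nitrogen, and it gives a step that the two limits leave unreadable from compound 1 to compound 2. Compound 3 `O=c1[nH]cc(S(=O)(=O)Nc2ccc(-c3cn(-c4cccc(F)c4)nn3)cc2)c(=O)[nH]1` also gives only a limit in this assay, > 20000 nM. The difference between the core of compound 1 and the core of compound 3 is not broken down here. All three values sit at the same point, (the limit of > 20000 nM in this assay, at which 3 of the 3 values shown sit).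

Compound 4 `O=c1[nH]cc(S(=O)(=O)Nc2ccc(-c3cn(-c4ccc(F)cc4)nn3)cc2)c(=O)[nH]1` is not yet measured; it differs from compound 3 by 4-fluorophenyl in place of 3-fluorophenyl on an aromatic nitrogen, the same change as that from compound 1 to compound 2. The step expected from compound 3 to compound 4 in this assay is a step that the limit leaves unreadable from compound 3 to compound 4, small because every measured value sits at the limit of > 20000 nM in this assay, at which 3 of the 3 values shown sit. Compound 4 is expected to give about 30000 nM, plausibly between 15000 nM and 100000 nM, most likely again as a limit.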

Compound 4, half-maximal inhibitory concentration: > 20000 nM
Compound 4 gave a limit, no number; the forecaster's own chance of this, stated with the estimate: 85%; the middle value lies beyond the limit too.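

Compound 3 and compound 4 both give only limits in this assay, so no step between them can be read: the limit of > 20000 nM in this assay, at which 4 of the 4 values shown sit.

Still open, as far as these compounds go, is whether 4-fluorophenyl in place of 3-fluorophenyl changes activity at all, and how the four compounds rank, as none gives a number.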